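Indazole to pyrrolopyridine on the shared core of compound 1

The source may hold more compounds than are shown below. What is called first, only, known or untested is meant among the compounds shown, and "the series" means these compounds.

Among the measured compounds shown here, compound 1 `CC(=O)N1CCCN(c2cccc(Nc3nccc(-c4n[nH]c5ccccc45)n3)c2)CC1` is one of three compounds measured in a functional assay on MV4-11 cells (Homo sapiens) for antiproliferative activity, read by resazurin assay, with a stated time of 72 h; a lower number here means a stronger inhibitor of growth, a higher number a weaker inhibitor of growth. In this assay compound 1 gives 18 nM, the lowest of the two numbers reported. Its nearest neighbour is compound 3 `CC(=O)N1CCN(c2ccc(Nc3nccc(-c4cn(S(=O)(=O)c5ccc(C)cc5)c5ccccc45)n3)cc2)CC1`, which in this assay gives 1560 nM, a higher number that lies beyond the scatter. Compound 2 `CC(=O)N1CCN(c2ccc(Nc3nccc(-c4c[nH]c5ncccc45)n3)cc2)CC1` is reported in this assay only as a limit, < 1 nM, and not as a number (the limit of < 1 nM in this assay, at which 1 of the 3 values shown sits). No two of these compounds differ in only one place, so no single step between measured compounds can be read off.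

Compound 4 `CC(=O)N1CCCN(c2cccc(Nc3nccc(-c4c[nH]c5cccnc45)n3)c2)CC1` has the same atoms as compound 1, joined differently (a group of 9 heavy atoms (7 carbon, 2 nitrogen; one five-membered aromatic ring with 1 hetero atom, one six-membered aromatic ring with 1 hetero atom) in place of a group of 9 heavy atoms (7 carbon, 2 nitrogen; one five-membered aromatic ring with 2 hetero atoms, one six-membered aromatic ring of carbon only), on an aromatic carbon). For the measured compounds named here, compound 2 carries a related five-membered ring with 1 hetero atom fused to a six-membered ring with 1 hetero atom and sits at the limit, but it also differs from compound 1 elsewhere, so its value shows only that such a group is compatible with strong growth inhibition.

On that basis compound 4 is expected to sit close to compound 1, with a step of a 1.8-fold lower number from compound 1 to compound 4 (0.26 log units; within the scatter) toward a somewhat lower number, within or just beyond the scatter. Compound 4 is estimated at 10 nM, within a range from 2 nM to 50 nM.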

Compound 4, concentration for 50% growth inhibition: 688 nM
The estimate for compound 4 lay 69-fold (1.84 log units) below the measured number, outside the stated range (above it).
By their numbers in this assay, from the lowest: compound 1; then compound 4; then compound 3. At a limit, below all of these: compound 2.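

Compound 4 shows that at this place on the shared core, on an aromatic carbon next to the ring nitrogen, growth inhibition depends on more than the composition of the group. The 1H-indazol-3-yl group and the group that replaces it have the same heavy atoms and the same counts of hydrogen-bond donors and acceptors, yet the exchange gives a 38-fold higher number from compound 1 to compound 4 (1.58 log units; beyond the scatter) in this assay. This is the first single-place step in the series, and it shows that the related ring pair in compound 2 cannot be carried over to the core of compound 1 with its strength intact; compound 2 differs from compound 1 elsewhere as well, and its value is a limit of the assay, not a number: the limit of < 1 nM in this assay, at which 1 of the 4 values shown sits.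

The compounds shown leave open which feature of the exchange accounts for the step, since only this one pair of ring groups is compared on this core. They also leave open whether an amine or a carboxylic acid on the entering group would recover any of the lost growth inhibition, or whether the step would be the same on the core of compound 2.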